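Swapping Cyclopentyl for 4-Fluorobenzyl at the Ether Oxygen

A few compounds are considered here, and "the series" means these few. Any claim that something is new, unique, unknown or untested is made for them only; others in the source may bear on it.

Within the data shown here, compound 1, `Cc1nn(-c2ncnc3nc[nH]c23)c2c1C(OC1CCCC1)CC(=O)N2`, gives 62 nM in a functional assay on HEK293 cells for agonist activity at G-protein coupled receptor 39 (Homo sapiens), read by scintillation proximity assay and inositol phosphate accumulation, with a stated time of 75 min (on this read-out higher numbers stand for an effect only at larger amounts of compound and lower numbers for an effect already at smaller amounts), the lowest of the two numbers measured so far. Among the measured compounds shown here, its only measured neighbour is compound 2, `Cc1nn(-c2ncnc3nc[nH]c23)c2c1C(OCc1ccc(C(C)C)cc1)CC(=O)N2`, which carries a 4-isopropylbenzyl group in place of the cyclopentyl; in this assay compound 2 gives 1690 nM. For the measured compounds named here, the single step that joins them, a 27-fold higher number from compound 1 to compound 2 (1.44 log units; beyond the scatter), shows that exchanging the cyclopentyl for a substituted benzyl group on that oxygen costs much activity.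

Compound 3, `Cc1nn(-c2ncnc3nc[nH]c23)c2c1C(OCc1ccc(F)cc1)CC(=O)N2`, has not yet been measured. It differs from compound 1 as follows: 4-fluorobenzyl in place of cyclopentyl on an oxygen on a saturated carbon. This is the same kind of exchange that the measured step describes, a cyclopentyl replaced by a benzyl group bearing a single substituent on the ring, although the substituent here is fluorine rather than isopropyl. Going by the values given here, the only step that bears on it therefore points towards a weaker compound, and a sizeable loss is expected, though the fluorine variant has no direct precedent here and the size of the loss is uncertain. Compound 3 is expected to give about 500 nM in this assay, within roughly 150 nM to 1700 nM, which corresponds to an estimated 8.1-fold higher number from compound 1 to compound 3 (0.91 log units; beyond the scatter).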

Compound 3, half-maximal effective concentration: 126 nM
Compound 3: middle estimate off by 4.0-fold (0.60 log units), on the high side; the measured number lies below the stated range.
By their numbers in this assay, from the lowest: compound 1; then compound 3; then compound 2.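

The benzyl group on this oxygen is far less costly than compound 2 alone suggested: 4-fluorobenzyl in place of cyclopentyl gives a 2.0-fold higher number from compound 1 to compound 3 (0.31 log units; beyond the scatter) in this assay and, although this modest step lies beyond the scatter, it is much smaller than the step seen with the 4-isopropylbenzyl group. With the benzyl group kept, fluoro in place of isopropyl on an aromatic carbon gives a 13-fold lower number from compound 2 to compound 3 (1.13 log units; beyond the scatter) and this large step shows that, among these three compounds, most of the loss in compound 2 goes with the isopropyl group rather than with the exchange of cyclopentyl for a benzyl group. Nothing in the available data accounts for the difference between these two ring substituents.

The compounds shown leave open whether a benzyl group with only hydrogen on its ring, or one carrying chloro or methoxy in place of the fluoro, would match compound 1 or fall further behind it. They also leave open how a cyclohexyl group, an open n-butyl chain or a benzyl group bearing an amine would compare on the same oxygen.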